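Methyl for Chloro on the Aryl Ring: Expected Cytotoxicity

The compounds below may be only part of what the source reports. "The series", "measured", "known", "first", "only" and "open" are said of these compounds alone.

Of the compounds shown here, two built on the same core have been measured so far. Compound 1 `Cc1ccc(-c2cs/c(=N/NC(=O)CSc3nnnn3C)n2-c2ccccc2)cc1` and compound 2 `O=C(CSc1ncccn1)N/N=c1/scc(-c2ccc(Cl)cc2)n1-c1ccccc1` were both tested in a functional assay on C6 cells (Rattus norvegicus) for cytotoxicity, read by MTT assay, with a stated time of 24 h, tested at 6 ug/mL; on this read-out lower numbers stand for a stronger effect and higher numbers for a weaker effect at the one concentration tested. In this assay compound 1 gives 88%, and compound 2 gives 95.9%. Compound 2 holds the highest of the two numbers, yet its gap to compound 1 lies within the usual scatter of repeated measurements, so the two readings cannot be told apart. Both readings are high, which on this read-out means only a weak effect at the one concentration tested.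

Compound 3 `Cc1ccc(-c2cs/c(=N/NC(=O)CSc3ncccn3)n2-c2ccccc2)cc1` has not yet been measured. It differs from compound 2 in a single place: methyl in place of chloro on an aromatic carbon. Compound 1 also carries a methyl at that position, and its reading sits within the scatter of compound 2. No step beyond the scatter is therefore expected in this assay, in either direction. The expected step of a number 4.9 percentage points lower from compound 2 to compound 3 (within the scatter) is small. Compound 3 is estimated to give 91%, with a likely range from 78% to 102%.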

Compound 3, a percentage reported as activity, at one concentration (the size of the read-out at that concentration, not a potency): 93.2%
Compound 3: middle estimate off by 2.2 percentage points, on the low side; low and high end bracket the measured number.
By their numbers in this assay, from the lowest: compounds 1, 3 and 2 (each within the scatter of the next).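

The change from 4-chlorophenyl to 4-methylphenyl can now be read on its own, with the rest of the molecule unchanged, and in this assay it gives a number 2.7 percentage points lower from compound 2 to compound 3 (within the scatter) so chloro and methyl cannot be told apart at this place on the ring, para to a large group. The new compound also allows a second clean comparison at the other end of the molecule: pyrimidin-2-yl in place of 1-methyl-1H-tetrazol-5-yl on the sulfur gives a number 5.2 percentage points higher from compound 1 to compound 3 (within the scatter) and so this change, too, leaves the reading indistinguishable from its partner's. Nothing measured here offers an explanation for either result.

The compounds shown carry only chloro or methyl on this aromatic carbon, so it remains open whether an amine or a carboxylic acid there would move the reading beyond the scatter. On these data alone, it is equally open whether a longer chain in place of the pyrimidin-2-yl group on the sulfur would separate from these three compounds in this assay at the one concentration tested.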